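This account rests on a few compounds, and the source may have more. Where it says the series, first, only, none or still open, it means among the compounds named here.

Compound 1 `O=C1C(Nc2ccc(I)cc2)=CC(=O)c2c1nc1n2[C@H]2OC[C@@H](O)[C@H]2OC1`: 4010 nM
Compound 2 `Cc1ccc(NC2=CC(=O)c3nc4n(c3C2=O)[C@H]2OC[C@@H](O)[C@H]2OC4)cc1`: 3860 nM

Of the compounds shown here, two have been tested in a functional assay on HeLa cells (Homo sapiens) for inhibition, read by sulforhodamine B assay; on this read-out higher numbers stand for weaker inhibition and lower numbers for stronger inhibition. Compound 1 gives 4010 nM, and compound 2 gives 3860 nM. Among the measured compounds shown here, the two numbers sit within the usual scatter of one another, so neither compound can be placed above or below the other; the series so far occupies a single, rather weak level of inhibition, and compound 1 is simply one of its two members.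

Compound 3 `CCOc1ccccc1NC1=CC(=O)c2c(nc3n2[C@H]2OC[C@@H](O)[C@H]2OC3)C1=O` is the next candidate. It keeps the shared core and changes only the group on the amine nitrogen: 2-ethoxyphenyl in place of 4-iodophenyl on an amine nitrogen. For the measured compounds named here, no measured pair in this set shows what such an exchange does, so the size and direction of the step cannot be read off existing data. What the two measured numbers do show is that a change of the group on the amine nitrogen has so far left the readout unmoved. On that basis compound 3 is expected to land close to compound 1, with a step of a 1.0-fold lower number from compound 1 to compound 3 (0.00 log units; within the scatter) that does not go beyond the scatter. Compound 3 is therefore estimated at 4000 nM, within a range from 1500 nM to 11000 nM.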

Compound 3, half-maximal inhibitory concentration: 8300 nM
The estimate for compound 3 lay 2.1-fold (0.32 log units) below the measured number; the range from low to high includes it.
By their numbers in this assay, from the lowest: compounds 2 and 1 (each within the scatter of the next); then compound 3.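

In this assay, 2-ethoxyphenyl in place of 4-iodophenyl on the amine nitrogen gives a 2.1-fold higher number from compound 1 to compound 3 (0.32 log units; beyond the scatter), a modest step beyond the scatter towards weaker inhibition. The group on this nitrogen can therefore move the read-out, which the two earlier compounds could not show, as their values lay within the scatter of each other. The exchange replaces an iodine with an ethoxy chain and also differs in the number that places the substituent in the group's name, but nothing measured here accounts for the step.

The compounds shown leave open whether the step belongs to the ethoxy group or to where it stands, as neither 4-ethoxyphenyl nor 2-iodophenyl appears among them to separate the two. They also leave open whether any group on this nitrogen can take inhibition beyond the single weak level seen so far, for instance a phenyl ring carrying a carboxylic acid or an amine, or a plain alkyl chain in place of the aromatic ring.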